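Amide aryl replacement on the shared core

The source may hold more compounds than are shown below. What is called first, only, known or untested is meant among the compounds shown, and "the series" means these compounds.

Among the compounds with values here, in a functional assay on NCI-H1975 cells (Homo sapiens) for antiproliferative activity, read by MTT assay, with a stated time of 72 h (a higher number here means a weaker inhibitor, a lower number a stronger inhibitor), compound 2 `COc1cc(F)c(NC(=O)c2ccncc2OC)cc1Nc1nccc(-c2cn(C)c3ccccc23)n1` gives 4120 nM, the lowest of the two numbers so far, with compound 1 `COc1cc(F)c(NC(=O)c2ccnc(Cl)c2)cc1Nc1nccc(-c2cn(C)c3ccccc23)n1` nearest at 4330 nM. Compound 3 `COc1cc(F)c(NC(=O)c2ccccn2)cc1Nc1nccc(-c2cn(C)c3ccccc23)n1` carries pyridin-2-yl in place of 3-methoxypyridin-4-yl on a carbonyl carbon. Within the data shown here, the only step bearing on this position, a 1.1-fold lower number from compound 1 to compound 2 (0.02 log units; within the scatter), left the number essentially unchanged. Two different aryl groups on this carbonyl gave the same outcome, so no step beyond the scatter is expected for a 1.0-fold higher number from compound 2 to compound 3 (0.01 log units; within the scatter), with the caveat that a third group at the same place rests on a single prior step. Compound 3 is accordingly estimated at 4200 nM in this assay, within a range of 1800 nM to 10000 nM.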

Compound 3, half-maximal inhibitory concentration: 16500 nM
Estimate against measurement, compound 3: 3.9-fold (0.59 log units) below, outside the stated range (above it).
By their numbers in this assay, from the lowest: compounds 2 and 1 (each within the scatter of the next); then compound 3.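

The group on this carbonyl is not interchangeable: pyridin-2-yl gives a weaker inhibitor than either earlier group, with (a 4.0-fold higher number from compound 2 to compound 3 (0.60 log units; beyond the scatter)) and (a 3.8-fold higher number from compound 1 to compound 3 (0.58 log units; beyond the scatter)), both modest steps. Compound 3 differs from compound 1 and compound 2 both in the ring's attachment, pyridin-2-yl rather than pyridin-4-yl, and in lacking their chloro or methoxy group, and these two changes cannot be separated here. No measurement available here explains the loss.

On these data alone, it remains open whether unsubstituted pyridin-4-yl would match compound 1 and compound 2 or follow compound 3. As far as these compounds go, how a phenyl ring or an amine-bearing pyridine would behave at this carbonyl is also open.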